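The compounds below may be only part of what the source reports. "The series", "measured", "known", "first", "only" and "open" are said of these compounds alone.

Compound 1 `COc1ccc(C2=C(c3cc(OC)c(OC)c(OC)c3)C(=O)CC2O[SiH2]C(C)(C)C)cc1`: > 100 ug/mL (a limit)
Compound 2 `COc1cc(C2=C(c3cc(C)c(OC)c(C)c3)C(O)CC2=O)cc(OC)c1OC`: > 100 ug/mL (a limit)
Compound 3 `COc1ccc(C2=C(c3cc(OC)c(OC)c(OC)c3)C(=O)CC2O[SiH2]C(C)(C)C)cc1OC`: > 100 ug/mL (a limit)

In an ADME assay on DU-145 cells (Homo sapiens) for cytotoxicity, read by MTT assay, with a stated time of 72 h (a higher number here means a weaker inhibitor, a lower number a stronger inhibitor), compound 3 gives > 100 ug/mL, which is a limit of the assay and not a number. Among the compounds with values here, it therefore has no exact place among the values so far, and all of them share one mark: the limit of > 100 ug/mL in this assay, at which 3 of the 3 values shown sit.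

Compound 4 `COCOc1cc(C2=C(c3cc(OC)c(OC)c(OC)c3)C(=O)CC2O[SiH2]C(C)(C)C)ccc1OC` differs from compound 3 in one place: methoxy in place of hydrogen on a saturated chain carbon bound to an oxygen on an aromatic ring. This is methoxy in place of hydrogen on a saturated chain carbon bound to an oxygen on an aromatic ring, which turns 3,4-dimethoxyphenyl into 4-methoxy-3-(methoxymethoxy)phenyl.

The nearest measured change is a step that the two limits leave unreadable from compound 1 to compound 3. It also adds a methoxy, but on an aromatic carbon, and it gives no size to carry over. Within the data shown here, no step of known size or direction can be expected in this assay, only that the result stays near the limit.

The expected change is a step that the limit leaves unreadable from compound 3 to compound 4.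

For compound 4 the estimated value is 130 ug/mL, with an expected range from 50 ug/mL to 300 ug/mL.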

Compound 4, half-maximal inhibitory concentration: 34 ug/mL
Beside the measured number, compound 4's estimate is 3.8-fold (0.58 log units) above it; measured number below the stated range.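

In this assay, within the data shown here, turning 3,4-dimethoxyphenyl into 4-methoxy-3-(methoxymethoxy)phenyl gives an at least 2.9-fold lower number from compound 3 to compound 4 (0.46 log units; beyond the scatter), the first sign that the group at this place on the aromatic ring can change the result. Methoxymethoxy in place of hydrogen on an aromatic carbon gives an at least 2.9-fold lower number from compound 1 to compound 4 (0.46 log units; beyond the scatter), whereas the simpler methoxy added on an aromatic carbon left a step that cannot be read. Compound 4 is the only compound shown that has moved off the mark shared by the others: the limit of > 100 ug/mL in this assay, at which 3 of the 4 values shown sit.

As far as these compounds go, the full size of both steps stays open. The data shown do not explain the gain. From the compounds shown here alone, it is also open whether an amine or a longer ether chain at this same place would lower the number further or raise it again.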